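The source may report more compounds than this note shows. Statements on the series, on what has been measured and on what is new or still open speak of the compounds shown alone.

Of the compounds shown here, three built on one shared core have been tested in a functional assay on PC-3 cells (Homo sapiens) for cytotoxicity, read by MTT assay, with a stated time of 72 h; a higher number here means a weaker inhibitor, a lower number a stronger inhibitor. Compound 1 `COc1cccc(/C=C/C(=O)Nc2cc(C(=O)c3cc(OC)c(OC)c(OC)c3)ccc2OC)c1` gives 4700 nM. Compound 2 `COc1ccc(C(=O)c2cc(OC)c(OC)c(OC)c2)cc1NC(=O)/C=C/c1ccc(F)c(F)c1` gives 8300 nM, and compound 3 `COc1cccc(/C=C/C(=O)Nc2cc(C(=O)c3cc(OC)c(OC)c(OC)c3)cc(OC)c2OC)c1` gives 13300 nM. Among these three numbers the one for compound 3 is the highest: the step of a 2.8-fold higher number from compound 1 to compound 3 (0.45 log units; beyond the scatter) lies beyond the scatter, whereas the numbers for compound 2 and compound 3 sit within the scatter of each other.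

Compound 4 `COc1cc(C(=O)c2cc(OC)c(OC)c(OC)c2)cc(NC(=O)/C=C/c2cc(F)c(F)c(F)c2)c1OC` has not yet been measured. It differs from compound 3 in one place: 3,4,5-trifluorophenyl in place of 3-methoxyphenyl on a double-bonded chain carbon bound to a double-bonded chain carbon. The closest guide is a 1.8-fold higher number from compound 1 to compound 2 (0.25 log units; within the scatter), a change of the same kind made in the same place on the chain, and that step stayed within the scatter. A similar outcome is expected here: no step beyond the scatter, with a slightly higher number if anything. The step expected from compound 3 to compound 4 is therefore a 1.5-fold higher number from compound 3 to compound 4 (0.18 log units; within the scatter). Compound 4 is thus estimated at 20000 nM in this assay, with a range from 8000 nM to 50000 nM.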

Compound 4, half-maximal inhibitory concentration: 7400 nM
Estimate against measurement, compound 4: 2.7-fold (0.43 log units) above, outside the stated range (below it).
By their numbers in this assay, from the lowest: compounds 1, 4, 2 and 3 (each within the scatter of the next, the first and the last beyond it).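

In this assay, putting 3,4,5-trifluorophenyl in place of 3-methoxyphenyl gives a 1.8-fold lower number from compound 3 to compound 4 (0.25 log units; within the scatter), so the two compounds cannot be told apart. Alongside a 1.8-fold higher number from compound 1 to compound 2 (0.25 log units; within the scatter), this shows that swapping 3-methoxyphenyl for a fluorinated phenyl at this place on the chain has now stayed within the scatter twice, both with and without the extra methoxy that separates compound 3 from compound 1. Nothing available explains why these swaps leave the number within the scatter.

From the compounds shown here alone, both swaps bring in fluorinated phenyl groups, so it remains open whether a phenyl carrying an amine or a carboxylic acid would also stay within the scatter. A longer chain in place of the double-bonded chain is equally untested among the compounds shown.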